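Longer Ether Chains at the Aromatic Oxygen

The compounds below may be only part of what the source reports. "The series", "measured", "known", "first", "only" and "open" are said of these compounds alone.

Compound 1, `CCc1sc(CCc2cc(OC(C)C)cc(NCc3cc(Cl)cc(NC(=O)OC(C)C)c3)n2)nc1C`: 12 nM
Compound 2, `CCc1sc(CCc2cc(OC3CCCCC3)cc(NCc3cc(Cl)cc(NC(=O)OC(C)C)c3)n2)nc1C`: 29 nM
Compound 3, `CCc1sc(CCc2cc(OCc3ccccc3)cc(NCc3cc(Cl)cc(NC(=O)OC(C)C)c3)n2)nc1C`: 237 nM

In an assay on cells for binding affinity to Neuropeptide Y receptor type 1 (Homo sapiens) (a lower number here means a stronger inhibitor, a higher number a weaker inhibitor), compound 1 gives the lowest number of the three, with compound 2 nearest and compound 3 furthest. Compound 4, `CCc1sc(CCc2cc(OCCCc3ccccc3)cc(NCc3cc(Cl)cc(NC(=O)OC(C)C)c3)n2)nc1C`, differs from compound 1 by 3-phenylpropyl in place of isopropyl on an oxygen on an aromatic ring. Among the compounds with values here, two measured steps bear on this change: a 2.4-fold higher number from compound 1 to compound 2 (0.38 log units; beyond the scatter), and a 20-fold higher number from compound 1 to compound 3 (1.30 log units; beyond the scatter). The benzyl group, which also brings in one six-membered aromatic ring of carbon only, gave the large step; 3-phenylpropyl brings the same ring on a longer chain. For compound 4 a rise beyond the scatter, likely between those two steps, is therefore expected, a 13-fold higher number from compound 1 to compound 4 (1.10 log units; beyond the scatter). Compound 4 is estimated at 150 nM, within a range from 40 nM to 600 nM.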

Compound 4, half-maximal inhibitory concentration: 20 nM
The estimate for compound 4 lay 7.5-fold (0.88 log units) above the measured number; the whole stated range lies above it.
By their numbers in this assay, from the lowest: compounds 1, 4 and 2 (each within the scatter of the next, the first and the last beyond it); then compound 3.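

In this assay a phenyl ring on this oxygen is not costly in itself: phenethyl in place of phenyl on the chain carbon gives a 12-fold lower number from compound 3 to compound 4 (1.07 log units; beyond the scatter), so the chain carrying the ring decides the outcome here. The long 3-phenylpropyl group also stays level with isopropyl, at a 1.7-fold higher number from compound 1 to compound 4 (0.22 log units; within the scatter), and with cyclohexyl, at a 1.5-fold lower number from compound 2 to compound 4 (0.16 log units; within the scatter), so this oxygen accepts a much larger group than compound 1 carries. Nothing available explains these numbers. Still open, going by these compounds, is how phenethyl on the oxygen, a longer chain, or an amine at the chain end would read.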